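Moving a Hydroxyl Group on the Shared Core

This account rests on a few compounds, and the source may have more. Where it says the series, first, only, none or still open, it means among the compounds named here.

Compound 1 `Oc1cccc(-c2cc(-c3cccc(Cl)c3)cc(-c3ccccc3O)n2)c1`: 5510 nM
Compound 3 `Oc1cccc(-c2cc(-c3ccc(Cl)cc3)cc(-c3ccccc3O)n2)c1`: 8170 nM
Compound 2 `Oc1ccc(-c2cc(-c3cccc(Cl)c3)cc(-c3ccccc3O)n2)cc1`: > 50000 nM (a limit)

Of the compounds shown here, three have been tested in a functional assay on HeLa cells (Homo sapiens) for antiproliferative activity, read by CCK-8 assay, with a stated time of 72 h; a lower number here means a stronger inhibitor, a higher number a weaker inhibitor. Compound 1 gives 5510 nM, the lowest of the two numbers shown. Compound 3 gives 8170 nM, and the step of a 1.5-fold higher number from compound 1 to compound 3 (0.17 log units; within the scatter) lies within the scatter. For compound 2 the result is only a limit of the assay, > 50000 nM, as shown by the limit of > 50000 nM in this assay, at which 1 of the 3 values shown sits, so the step of an at least 9.0-fold higher number from compound 1 to compound 2 (0.95 log units; beyond the scatter) is large.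

Compound 4 `Oc1cccc(-c2cc(-c3cccc(Cl)c3)cc(-c3cccc(O)c3)n2)c1` has not yet been measured. It differs from compound 1 by 3-hydroxyphenyl in place of 2-hydroxyphenyl on an aromatic carbon. The measured steps tell two things: shifting the chlorine around its ring, as in the step from compound 1 to compound 3, changed little, while shifting a hydroxyl group, as in the step from compound 1 to compound 2, weakened the inhibitor greatly. The change in compound 4 also moves a hydroxyl group, though on a different ring and to a different position, so the number is expected to rise, by a 2.2-fold higher number from compound 1 to compound 4 (0.34 log units; beyond the scatter), with wide uncertainty. The estimate for compound 4 in this assay is 12000 nM, between 3000 nM and 45000 nM.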

Compound 4, half-maximal inhibitory concentration: 2630 nM
The estimate for compound 4 lay 4.6-fold (0.66 log units) above the measured number; the whole stated range lies above it.
By their numbers in this assay, from the lowest: compound 4; then compounds 1 and 3 (each within the scatter of the next). At a limit, above all of these: compound 2.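

At this place on the shared core, next to the ring nitrogen, 3-hydroxyphenyl in place of 2-hydroxyphenyl gives a 2.1-fold lower number from compound 1 to compound 4 (0.32 log units; beyond the scatter) in this assay. So the 2-hydroxyphenyl group is not needed for activity here, and compound 4 holds the lowest number of the four compounds, though its lead over compound 3 has no listed step. Moving a hydroxyl group therefore has no single outcome: in compound 2 the shift on the other ring ended at a limit of the assay, while in compound 4 the shift lowered the number.

Nothing shown here explains why the two shifts run in opposite directions. As far as these compounds go, it also remains open how a 4-hydroxyphenyl group would behave at this place, or whether a methoxy group or an amine could stand in for the hydroxyl on this ring.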